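Methoxy-to-cyano swaps in an aryl ether series

The source may hold more compounds than are shown below. What is called first, only, known or untested is meant among the compounds shown, and "the series" means these compounds.

Measured so far in a physicochemical assay for lipophilicity, at pH 7.4; a higher number here means a more lipophilic compound, a lower number a more polar compound:
compound 1 `COc1ccccc1OCc1cc(C)nc(-c2ccccn2)n1`: 2.5
compound 2 `COc1cccc(OCc2cc(C)nc(-c3ccccn3)n2)c1`: 2.9
compound 3 `Cc1cc(COc2ccccc2C#N)nc(-c2ccccn2)n1`: 2.7

Compound 1 and compound 2 have the same atoms joined differently; the difference between the two cores is not broken down here. Compound 2 lies a gap beyond the scatter above compound 1, while compound 2 and compound 3 lie within the scatter of each other.

From compound 1 to compound 3 the change is cyano in place of methoxy on an aromatic carbon. The step was a number 0.20 log units higher from compound 1 to compound 3 (within the scatter).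

Compound 4 `Cc1cc(COc2cccc(C#N)c2)nc(-c2ccccn2)n1` is not yet measured in this assay. It differs from compound 2 by cyano in place of methoxy on an aromatic carbon. The place is not the same word for word: in compound 3 the cyano stands ortho to a large group, in compound 4 meta to a large group, so this is the same kind of change, not the same change.

The step from compound 2 to compound 4 in this assay is expected to be a number 0.20 log units higher from compound 2 to compound 4 (within the scatter). This rests on compound 1 and compound 3, because the same kind of change gave a number 0.20 log units higher from compound 1 to compound 3 (within the scatter). Compound 4 is therefore estimated at 3.1, expected between 2.8 and 3.4.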

Compound 4, distribution coefficient: 2.7
Compound 4: middle estimate off by 0.40 log units, on the high side; measured number outside the range, below it.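

In this assay the swap of cyano in place of methoxy on an aromatic carbon gives a number 0.20 log units lower from compound 2 to compound 4 (within the scatter), and on the other core it gave a number 0.20 log units higher from compound 1 to compound 3 (within the scatter). Both steps lie within the scatter, so neither pair resolves an effect of the swap, and these two pairs do not show that a step read on one core sets the direction of the step on the other, nor that the two cores respond differently, as the cyano also stands in a different place in each pair. Nothing shown here accounts for the numbers.

Going by these compounds, with only these two pairs, it stays open whether this swap ever moves this assay beyond the scatter on either core. On these data alone, it also stays open how an amine or a carboxylic acid in the same place on the aromatic ring would read against the methoxy and cyano compounds.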